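A few compounds are considered here, and "the series" means these few. Any claim that something is new, unique, unknown or untested is made for them only; others in the source may bear on it.

Working notes on the series. In a functional assay on K562 cells (Homo sapiens) for inhibition, read by spectrophotometry and sulforhodamine B assay, with a stated time of 48 h (a higher number here means a weaker inhibitor of growth, a lower number a stronger inhibitor of growth), compound 2 `O=C1CS/C(=N/N=C/c2c[nH]c3ccccc23)N1c1cccc2ccccc12` gives > 100000 nM, which is a limit of the assay and not a number. Compound 4 `O=C1CS/C(=N/N=C/c2c[nH]c3ccc(Br)cc23)N1c1cccc2ccccc12` departs from compound 2 by bromo in place of hydrogen on an aromatic carbon. Two other compounds carry bromo and both give numbers in this assay: compound 1 `Cc1ccc(N2C(=O)CS/C2=N/N=C/c2c[nH]c3ccc(Br)cc23)cc1` gives 10 nM and compound 3 `S=C(N/N=C/c1c[nH]c2ccc(Br)cc12)Nc1cccc2ccccc12` gives 5290 nM. Among the compounds with values here, these two values lie far apart, and no measured pair isolates the bromo change, so its size cannot be read directly. The expectation is a large move towards stronger growth inhibition, resting on compound 1 at 10 nM and compound 3 at 5290 nM. Its size stays loosely bounded, and compound 4 could still end at a limit of the assay. The estimated change is an at least 50-fold lower number from compound 2 to compound 4 (1.69 log units; beyond the scatter). For compound 4 the expected value is 2000 nM, with an estimated range from 100 nM to 50000 nM.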

Compound 4, concentration for 50% growth inhibition: > 100000 nM
Compound 4: only a limit was reported (the forecaster's own chance of this, stated with the estimate: 15%); at least 50-fold (1.69 log units) between middle value and limit.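

Compound 2 and compound 4 both stand at a limit of the assay and not at a number, so no step between them can be read: the limit of > 100000 nM in this assay, at which 2 of the 4 values shown sit.

The compounds shown leave open whether bromo in place of hydrogen on an aromatic carbon changes growth inhibition at all in this pair.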